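Methoxy in place of pyridyl on the shared core

The source may hold more compounds than are shown below. What is called first, only, known or untested is meant among the compounds shown, and "the series" means these compounds.

Compound 1 `C=CC(=O)Nc1cccc(Nc2ncnc(Nc3ccc(-c4cccnc4)cc3)n2)c1` is the reference point of this set. In a functional assay on Ramos cells (Homo sapiens) for antiproliferative activity, read by CCK-8 assay, with a stated time of 24 h (on this read-out lower numbers stand for stronger inhibition and higher numbers for weaker inhibition), compound 1 gives > 100000 nM, which is a limit of the assay and not a number. Compound 2 `C=CC(=O)Nc1cccc(Nc2ncnc(Nc3ccc(Oc4ccc(OC)cc4)cc3)n2)c1` gives > 100000 nM in this assay, again a limit. Compound 3 `C=CC(=O)Nc1cccc(Nc2nc(Cl)nc(Nc3ccc(OCCOC)cc3)n2)c1` shows "not determined" (no result reported) in this assay. The step that the two limits leave unreadable from compound 1 to compound 2 cannot be read because both of its values sit at the limit of > 100000 nM in this assay, at which 2 of the 3 values shown sit. Compound 4 `C=CC(=O)Nc1cccc(Nc2ncnc(Nc3ccc(OC)cc3)n2)c1` differs from compound 1 by methoxy in place of pyridin-3-yl on an aromatic carbon. Going by the values given here, no measured step bears directly on this change; the single measured pair shows two limits only. With both measured analogues at the limit, compound 4 is expected to stay without measurable inhibition, the expected step being an at least 1.2-fold lower number from compound 1 to compound 4 (0.09 log units; that floor lies within the scatter). The estimate for compound 4 is 80000 nM, within 20000 nM to 300000 nM.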

Compound 4, half-maximal inhibitory concentration: 90000 nM
Compound 4: middle estimate off by 1.1-fold (0.05 log units), on the low side, within the range that was stated.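

Methoxy on an aromatic carbon, para to a large group, gives the first readable number on the shared core in this assay: compound 4 gives 90000 nM. Methoxy in place of pyridin-3-yl gives an at least 1.1-fold lower number from compound 1 to compound 4 (0.04 log units; that floor lies within the scatter), and methyl in place of 4-methoxyphenyl on the oxygen gives an at least 1.1-fold lower number from compound 2 to compound 4 (0.04 log units; that floor lies within the scatter). Both steps are floors only, and compound 1 and compound 2 remain limits, not numbers: the limit of > 100000 nM in this assay, at which 2 of the 4 values shown sit.

From the compounds shown here alone, whether an amine, a carboxylic acid or a longer chain at this place would move the number beyond the scatter stays open. Going by these compounds, the true distance from compound 1 and compound 2 to compound 4 also stays unknown.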